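Series notes: aryl change on the amide-type nitrogen

The source may report more compounds than this note shows. Statements on the series, on what has been measured and on what is new or still open speak of the compounds shown alone.

Compound 1 `S=C(N/N=C/c1ccc2ccccc2n1)Nc1cccc(Br)c1` is the only numbered point in a functional assay on HT-29 cells (Homo sapiens) for antiproliferative activity, read by sulforhodamine B assay, with a stated time of 72 h (on this read-out lower numbers stand for stronger inhibition and higher numbers for weaker inhibition), where compound 1 gives 58900 nM. Compound 2 `NC(=S)N/N=C/c1cnc2ccccc2n1` reaches only a limit of the assay in this assay, reported as > 100000 nM; this value is a limit and not a number. Compound 3 `Cc1ccccc1NC(=S)N/N=C/c1ccc2ccccc2n1` differs from compound 1 by 2-methylphenyl in place of 3-bromophenyl on an amide-type nitrogen. Within the data shown here, no measured step of this kind exists in the set, so little movement beyond the usual scatter is expected in this assay. The expected step of a 1.1-fold higher number from compound 1 to compound 3 (0.04 log units; within the scatter) is therefore small. Compound 3 is estimated to give 65000 nM in this assay, within 20000 nM to 200000 nM.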

Compound 3, half-maximal inhibitory concentration: 42300 nM
Estimate against measurement, compound 3: 1.5-fold (0.19 log units) above, and the stated range covers the measured number.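

In this assay, the step at this position, a 1.4-fold lower number from compound 1 to compound 3 (0.14 log units; within the scatter), shows that 2-methylphenyl can take the place of 3-bromophenyl on an amide-type nitrogen without a change beyond the scatter. This single pair does not separate the two aryl groups. Nothing available here bears on a cause for this step.

Still open, going by these compounds, is whether an amine or a longer alkyl chain on this nitrogen would hold the same level. Compound 2 gives > 100000 nM, which is a limit and not a number, and it differs from compound 1 in more than one place.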